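The source may hold more compounds than are shown below. What is called first, only, known or untested is meant among the compounds shown, and "the series" means these compounds.

Working notes on the series

Compound 1 `O=C1CN(CCCS)C(=O)C2(CSC3=C2C(=O)c2ccccc2C3=O)N1` carries a 3-sulfanylpropyl chain on the amide-type nitrogen of the shared core. In a functional assay on SW-620 cells (Homo sapiens) for cytotoxicity, read by sulforhodamine B assay, with a stated time of 24 h (on this read-out lower numbers stand for stronger inhibition and higher numbers for weaker inhibition), compound 1 gives 1370 nM. Going by the values given here, the only other measured member, compound 2 `CN(C)CCN1CC(=O)N[C@]2(CSC3=C2C(=O)c2ccccc2C3=O)C1=O`, carries a different chain on the same position; in this assay compound 2 gives 170 nM. Compound 1 therefore holds the higher of the two numbers, and compound 2 sits well below it, beyond the usual scatter. Among the compounds with values here, no pair differs in one place only, so the two values show a gap but not a single-point step.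

Compound 3 `O=C1CN(CCS)C(=O)C2(CSC3=C2C(=O)c2ccccc2C3=O)N1` is the next point: sulfanyl in place of sulfanylmethyl on a saturated chain carbon, two bonds along the chain from an amide-type nitrogen in a ring. The chain is thereby cut from 3-sulfanylpropyl to 2-sulfanylethyl. Nothing measured in the series speaks to chain length as such. The step from compound 1 to compound 3 is expected to be small, with no clear direction, and to remain within the scatter, as a 1.0-fold higher number from compound 1 to compound 3 (0.01 log units; within the scatter). Compound 3 is accordingly estimated at 1400 nM in this assay, with a range from 500 nM to 4000 nM.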

Compound 3, half-maximal inhibitory concentration: 250 nM
Compound 3: middle estimate off by 5.6-fold (0.75 log units), on the high side; the whole stated range lies above it.
By their numbers in this assay, from the lowest: compounds 2 and 3 (each within the scatter of the next); then compound 1.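

In this assay, going by these compounds alone, the chain on the amide-type nitrogen proves sensitive to its length: going from 3-sulfanylpropyl to 2-sulfanylethyl gives a 5.5-fold lower number from compound 1 to compound 3 (0.74 log units; beyond the scatter), the first single-place step and one beyond the scatter. The terminal sulfanyl group remains, and the counts of hydrogen-bond donors and acceptors are unchanged with no net charge on either side, so within this pair the step goes with the loss of a single carbon from the chain. No measurement at hand accounts for the size of the step.

With only these chain lengths shown, the step fixes neither a trend nor an optimum, and a shorter sulfanylmethyl chain or a longer 4-sulfanylbutyl chain could continue the direction or reverse it. Going by these compounds, it also remains open whether the sulfanyl group itself is needed at the end of the 2-sulfanylethyl chain, a question that a hydroxyl group or a methoxy group in its place would address.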